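Mirror-image of compound 3: expectation for compound 4

The source may report more compounds than this note shows. Statements on the series, on what has been measured and on what is new or still open speak of the compounds shown alone.

Compound 1 `COc1cc(C(c2ccc(O)c(OC)c2)[C@@H](C)[C@H](C)CO)ccc1O` gives > 100000 nM in a functional assay on HL-60 cells (Homo sapiens) for cytotoxicity, read by WST assay, with a stated time of 48 h (on this read-out lower numbers stand for stronger inhibition and higher numbers for weaker inhibition), which is a limit of the assay and not a number, namely (the limit of > 100000 nM in this assay, at which 1 of the 3 values shown sits). Among the measured compounds shown here, compound 2 `COC[C@@H](C)[C@H](C)C(c1ccc(O)c(OC)c1)c1ccc(O)c(OC)c1` gives 73000 nM in this assay, and the single measured step, an at least 1.3-fold lower number from compound 1 to compound 2 (0.13 log units; that floor lies within the scatter), does not exceed the scatter. Compound 3 `COc1ccc(C(c2ccc(OC)c(OC)c2)[C@H](C)[C@@H](C)CO)cc1OC` gives 47000 nM in this assay; this is the smaller of the two numbers shown, but the gap to compound 2 lies within the scatter, so the two cannot be told apart. Compound 4 `COc1ccc(C(c2ccc(OC)c(OC)c2)[C@@H](C)[C@H](C)CO)cc1OC` is the mirror image of compound 3: the two compounds have the same atoms and bonds and differ only in configuration as drawn: 2 of 2 stereo elements differ (all stereocentres are inverted: mirror images); a stereocentre at a saturated chain carbon is drawn S in compound 3 and R in compound 4; a stereocentre at a saturated chain carbon is drawn R in compound 3 and S in compound 4. No measured step changes configuration alone, and the one step shown concerns methylation of a hydroxyl on a saturated carbon, so nothing among the measured pairs bears directly on this change. With no evidence for a shift in either direction, the expected step of no change at the digits printed from compound 3 to compound 4 (within the scatter) is none beyond the scatter. Compound 4 is therefore estimated at 47000 nM in this assay, with a range from 18000 nM to 120000 nM.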

Compound 4, half-maximal inhibitory concentration: > 100000 nM
Compound 4: a limit, no number; the forecaster's own chance of this, stated with the estimate: 25%; middle value at least 2.1-fold (0.32 log units) from the limit.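

Inverting both stereocentres on the saturated chain is the first change of configuration alone among these compounds, and in this assay it gives an at least 2.1-fold higher number from compound 3 to compound 4 (0.32 log units; beyond the scatter). Configuration at this position therefore counts on this read-out, and the shift can be put down to configuration alone: the fact that compounds 3 and 4 differ only in the configuration as drawn. The value of compound 4 is a limit and not a number, so only a floor on the step can be read: the limit of > 100000 nM in this assay, at which 2 of the 4 values shown sit.

The compounds shown leave open whether one of the two stereocentres carries the shift alone or both are needed. Also open, going by these compounds, is whether the gap between the mirror images persists with an amine or a carboxylic acid in place of the hydroxyl on the saturated chain.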